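The compounds below may be only part of what the source reports. "The series", "measured", "known", "first", "only" and "open" are said of these compounds alone.

Working notes on the series.

Compound 1 `Cc1ccc(-c2nc3ccc(Br)cn3c2/C=N/OCc2cn(Cc3ccc(C#N)cc3)nn2)cc1` in a functional assay on the whole organism (strain NMRI) with Mus musculus as the target, with a stated time of 4 h (a higher number here means that more compound is needed for the effect, a lower number that less compound is needed), gives 40 mg/kg. Compound 2 `N#Cc1ccc(Cn2cc(CO/N=C/c3c(-c4ccccc4)nc4ccc(Br)cn34)nn2)cc1` differs from it by hydrogen in place of methyl on an aromatic carbon, and in this assay compound 2 gives 20 mg/kg. That step, a 2.0-fold lower number from compound 1 to compound 2 (0.30 log units; within the scatter), leaves the two numbers within the scatter of each other, so no order between compound 1 and compound 2 is claimed. Among the two numbers so far, compound 2 holds the lower one, with compound 1 as its only neighbour.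

Compound 3 `N#Cc1ccc(Cn2cc(CO/N=C/c3c(-c4ccc(F)cc4)nc4ccc(Br)cn34)nn2)cc1` is the next member, not yet measured. It differs from compound 2 by fluoro in place of hydrogen on an aromatic carbon, on an aromatic carbon of a six-membered aromatic ring of carbon only, para to a large group; cut one bond further out the change reads phenyl to 4-fluorophenyl. Within the data shown here, the only measured step, the exchange of methyl for hydrogen between compound 1 and compound 2, is a change at the same ring but of a different group, and it stayed within the scatter. Among the measured compounds shown here, no step with fluoro entering is available. The expectation for compound 3 is therefore a step of about no change at the digits printed from compound 2 to compound 3 (within the scatter), that is, nothing beyond the scatter. Compound 3 is estimated at 20 mg/kg in this assay, within a range of 10 mg/kg to 40 mg/kg.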

Compound 3, minimum effective dose: 100 mg/kg
Compound 3: the middle estimate sits 5.0-fold (0.70 log units) below what was measured; the whole stated range lies below it.
By their numbers in this assay, from the lowest: compounds 2 and 1 (each within the scatter of the next); then compound 3.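

At the place para to a large group, on the six-membered aromatic ring of carbon only, the series now shows a step beyond the scatter in this assay: fluoro in place of hydrogen gives a 5.0-fold higher number from compound 2 to compound 3 (0.70 log units; beyond the scatter). Fluoro in place of methyl at the same place points the same way, with a 2.5-fold higher number from compound 1 to compound 3 (0.40 log units; beyond the scatter), so more compound is needed with fluoro than with either of the other two groups, while hydrogen and methyl remain unseparated. No measurement on these compounds bears on the reason for the step, so the result stands as an observation only.

With only hydrogen, methyl and fluoro at this place, the compounds shown leave open whether the higher number is particular to fluoro or would recur with chloro, methoxy or an amine. Among these compounds, they also leave open whether the phenyl to 4-fluorophenyl change would give a step of similar size on a different core, since this exchange is seen only once, against the single background of compound 2.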